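The source may report more compounds than this note shows. Statements on the series, on what has been measured and on what is new or still open speak of the compounds shown alone.

Measured so far:
compound 1, `CC(C)n1c(SCc2ccccc2Cl)nc2cc(NC(=O)C3CC3)ccc21`: 6300 nM
compound 2, `COc1ccc([N+](=O)[O-])cc1CSc1nc2cc(NC(=O)NC(C)(C)C)ccc2n1C1CC1`: 79 nM

Going by the values given here, in an assay on isolated protein for inhibition of Gonadotropin-releasing hormone receptor (Homo sapiens) (on this read-out lower numbers stand for stronger inhibition and higher numbers for weaker inhibition), compound 2 gives the lower of the two numbers so far; compound 1 sits far higher, and the gap between them lies well beyond the scatter. The two measured compounds differ at several places at once, so no single change among them can be tied to a size of step.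

Compound 3, `CCn1c(SCc2cc([N+](=O)[O-])ccc2OC)nc2cc(NC(=O)NC(C)(C)C)ccc21`, keeps everything of compound 2 except one group on the bicyclic core: ethyl in place of cyclopropyl on an aromatic nitrogen. The replaced group and the new one are both small and uncharged, with no donors or acceptors in either.

With no step between measured compounds to lean on, the account can only reason from the kind of change. A swap of this size on the ring nitrogen is expected to move this assay little, most likely toward a slightly higher number for compound 3, of a size near the scatter rather than beyond it. For compound 3 the expected shift is a 1.9-fold higher number from compound 2 to compound 3 (0.28 log units; within the scatter). Compound 3 is therefore estimated at 150 nM, with a plausible range from 40 nM to 600 nM.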

Compound 3, half-maximal inhibitory concentration: 42 nM
Compound 3: the middle estimate sits 3.6-fold (0.55 log units) above what was measured, and the stated range covers the measured number.
By their numbers in this assay, from the lowest: compounds 3 and 2 (each within the scatter of the next); then compound 1.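

In this assay, going by these compounds alone, the exchange of cyclopropyl for ethyl on the aromatic nitrogen gives a 1.9-fold lower number from compound 2 to compound 3 (0.27 log units; within the scatter) and is the first change that can be read at a single place. At this position, with the rest of compound 2 held fixed, the three-membered ring can give way to the open two-carbon ethyl with a step that stays within the scatter, so the two groups cannot be told apart on this read-out. Nothing at hand bears on why these two groups read alike.

The compounds shown leave open how far this holds on the same nitrogen, since a hydrogen, a longer chain such as butyl, or a chain ending in an amine or a carboxylic acid could give a very different number. They also leave open whether ethyl and cyclopropyl would still read alike with other groups elsewhere on the molecule, as compound 1 differs from both compound 2 and compound 3 at several places at once.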